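From Ethoxy to (2-Methoxyethyl)amino on the Carbonyl Carbon

This account rests on a few compounds, and the source may have more. Where it says the series, first, only, none or still open, it means among the compounds named here.

Measured compounds:
compound 1 `CCOC(=O)c1c(-c2ccc(OC)c(OC)c2)csc1N`, 100%
compound 2 `COc1ccc(-c2csc(N)c2C(=O)OCc2ccc(C)cc2)cc1OC`, 50%
compound 3 `CCNC(=O)c1c(-c2ccc(OC)c(OC)c2)csc1N`, 50%

In an assay on isolated protein for inhibition of protein kinase C zeta type (Homo sapiens), with stated times of 1 h and 2.5 min, tested at 30 uM (a higher number here means more inhibition at the concentration tested (going by the name of the read-out), a lower number less inhibition), compound 1 gives 100%, the highest of the three numbers; compound 2 and compound 3 both sit a long way beneath it, as the steps of a number 50 percentage points lower from compound 1 to compound 2 (beyond the scatter) and a number 50 percentage points lower from compound 1 to compound 3 (beyond the scatter) show, and between compound 2 and compound 3 there is no change at the digits printed from compound 2 to compound 3 (within the scatter).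

Compound 4 `COCCNC(=O)c1c(-c2ccc(OC)c(OC)c2)csc1N` is not yet measured in this assay. Relative to compound 1 it carries the change ((2-methoxyethyl)amino in place of ethoxy on a carbonyl carbon).

The step that bears most directly on it is a number 50 percentage points lower from compound 1 to compound 3 (beyond the scatter), where ethylamino replaced ethoxy on the same carbonyl carbon; compound 4 makes the same kind of exchange with a (2-methoxyethyl)amino group, and compound 2 adds that every change away from compound 1 in this set cost a large amount. A large drop is therefore expected in this assay, roughly matching the step to compound 3, which would place compound 4 at an estimated 50% (range 20% to 85%), a step of a number 50 percentage points lower from compound 1 to compound 4 (beyond the scatter).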

Compound 4, a percentage reported as inhibition, at one concentration (the size of the read-out at that concentration, not a potency): 55%
Compound 4: the middle estimate sits 5 percentage points below what was measured; the measured number falls inside the stated range.
By their numbers in this assay, from the lowest: compounds 2, 3 and 4 (each within the scatter of the next); then compound 1.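

In this assay, (2-methoxyethyl)amino on the carbonyl carbon gives a number 45 percentage points lower from compound 1 to compound 4 (beyond the scatter), so the loss seen with ethylamino is repeated with a second, longer amino group in place of ethoxy. Methoxy in place of hydrogen on the saturated chain gives a number 5 percentage points higher from compound 3 to compound 4 (within the scatter), and (2-methoxyethyl)amino in place of (4-methylbenzyl)oxy gives a number 5 percentage points higher from compound 2 to compound 4 (within the scatter), so compound 2, compound 3 and compound 4 form one group well under compound 1, whether the replacement is bound through oxygen or nitrogen. Nothing measured here accounts for the loss at this position.

The compounds shown leave open how a methoxy, a dimethylamino or a free carboxylic acid on this carbonyl carbon would read in this assay. They also leave open whether any group other than ethoxy can match compound 1 there.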